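Swapping the ring on the unsaturated amide chain

The compounds below may be only part of what the source reports. "The series", "measured", "known", "first", "only" and "open" are said of these compounds alone.

Of the compounds shown here, three sharing one core have been tested in a functional assay on A549 cells (Homo sapiens) for antiproliferative activity, read by MTT assay, with a stated time of 48 h; a higher number here means a weaker inhibitor, a lower number a stronger inhibitor. Compound 1 `Clc1cccc(Nc2ncnc3ccc(NCc4cccc(Br)n4)cc23)c1` gives 2950 nM, compound 2 `Clc1cccc(Nc2ncnc3ccc(NCc4ccc(Br)s4)cc23)c1` gives 820 nM, and compound 3 `O=C(/C=C/c1cccs1)Nc1ccc2ncnc(Nc3cccc(Cl)c3)c2c1` gives 9310 nM, the highest of the three numbers; the steps of a 3.2-fold higher number from compound 1 to compound 3 (0.50 log units; beyond the scatter) and an 11-fold higher number from compound 2 to compound 3 (1.06 log units; beyond the scatter) both run upward to it. Compound 4 `O=C(/C=C/c1cccnc1Cl)Nc1ccc2ncnc(Nc3cccc(Cl)c3)c2c1` differs from compound 3 in one place: 2-chloropyridin-3-yl in place of thiophen-2-yl on a double-bonded chain carbon bound to a double-bonded chain carbon. The step that bears most on this is a 3.6-fold lower number from compound 1 to compound 2 (0.56 log units; beyond the scatter), where moving from a six-membered ring with one nitrogen to a five-membered ring with one sulfur, though at a different place and with a bromine rather than a chlorine, lowered the number. The change to compound 4 runs the other way, from the sulfur ring to the nitrogen ring, so a modest rise in this assay is expected, with wide uncertainty since the place and the halogen differ. The number for compound 4 is estimated at 16000 nM, between 5000 nM and 50000 nM, an expected step of a 1.7-fold higher number from compound 3 to compound 4 (0.24 log units; within the scatter).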

Compound 4, half-maximal inhibitory concentration: 2920 nM
Beside the measured number, compound 4's estimate is 5.5-fold (0.74 log units) above it, outside the stated range (below it).
By their numbers in this assay, from the lowest: compound 2; then compounds 4 and 1 (each within the scatter of the next); then compound 3.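

On the unsaturated amide chain, the ring at the end is not a silent part of the molecule: in this assay 2-chloropyridin-3-yl in place of thiophen-2-yl gives a 3.2-fold lower number from compound 3 to compound 4 (0.50 log units; beyond the scatter) with nothing else changed. The earlier step of a 3.6-fold lower number from compound 1 to compound 2 (0.56 log units; beyond the scatter) went from a nitrogen ring to a sulfur ring and lowered the number, whereas here going from a sulfur ring to a nitrogen ring lowers it too, so the direction seen on the saturated chain, with its bromine-bearing rings, does not carry over to this place. Nothing measured here explains that difference.

On these data alone, this change brings in a ring nitrogen and a chlorine together, so their separate shares stay open. A plain pyridin-3-yl or a 2-chlorophenyl on the same chain would be needed to tell them apart.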